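Swapping the methoxy-bearing benzyl for a methyl-bearing one

The source may hold more compounds than are shown below. What is called first, only, known or untested is meant among the compounds shown, and "the series" means these compounds.

Compound 3 `COc1cccc(CN2CCC(NC(=O)c3ccc4ccccc4c3)CC2)c1` gives 16 nM in an assay on isolated protein for displacement of a labelled ligand from D(4) dopamine receptor (Homo sapiens) (on this read-out higher numbers stand for weaker inhibition and lower numbers for stronger inhibition), the lowest of the three numbers measured. Compound 1 `O=C(NC1CCN(Cc2ccc(Cl)cc2)CC1)c1ccc2ccccc2c1` gives 37 nM and compound 2 `O=C(NC1CCN(Cc2cccc(Br)c2)CC1)c1ccc2ccccc2c1` gives 36 nM. The step of a 1.0-fold lower number from compound 1 to compound 2 (0.01 log units; within the scatter) lies within the scatter, whereas a 2.3-fold lower number from compound 1 to compound 3 (0.36 log units; beyond the scatter) and a 2.3-fold lower number from compound 2 to compound 3 (0.35 log units; beyond the scatter) are modest gains. Compound 4 `Cc1ccccc1CN1CCC(NC(=O)c2ccc3ccccc3c2)CC1` carries 2-methylphenyl in place of 3-methoxyphenyl on a saturated chain carbon bound to an amine nitrogen in a ring. For the measured compounds named here, no measured step tests a methyl group at this place; the only guidance is that compound 1 and compound 2 sit modestly higher than compound 3, so a small loss, if anything, is expected. Compound 4 is therefore expected to give about 30 nM, with a range from 12 nM to 80 nM. This corresponds to an expected step of a 1.9-fold higher number from compound 3 to compound 4 (0.27 log units; within the scatter).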

Compound 4, inhibition constant: 26 nM
Compound 4: the middle estimate sits 1.2-fold (0.06 log units) above what was measured, and the stated range covers the measured number.
By their numbers in this assay, from the lowest: compounds 3, 4, 2 and 1 (each within the scatter of the next, the first and the last beyond it).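

Of the compounds shown, only compound 4 carries 2-methylphenyl at this place, and this assay does not separate it from any of the others: the steps are a 1.6-fold higher number from compound 3 to compound 4 (0.21 log units; within the scatter) and a 1.4-fold lower number from compound 2 to compound 4 (0.14 log units; within the scatter) and a 1.4-fold lower number from compound 1 to compound 4 (0.15 log units; within the scatter). A phenyl ring with a plain methyl, and with no oxygen or halogen, therefore gives a number within the scatter of the methoxy, bromo and chloro compounds. No available measurement explains this result.

Still open, on these data alone, is whether 3-methylphenyl or 4-methylphenyl would give a similar number. It is also unknown how a phenyl ring bearing an amine or a carboxylic acid would fare at this place.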